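The source may report more compounds than this note shows. Statements on the series, on what has been measured and on what is new or still open speak of the compounds shown alone.

Compounds measured so far:
compound 1, `CCCCCCCCCCCOC(=O)CCC(=O)N1CCN(CCCOc2cc3c(Nc4ccc(F)c(Cl)c4)ncnc3cc2OC)CC1`: 12%
compound 2, `CCCCCCCCCCCCOC(=O)CCC(=O)N1CCN(CCCOc2cc3c(Nc4ccc(F)c(Cl)c4)ncnc3cc2OC)CC1`: 5.7%
compound 3, `CCCCCCCCCCCCCCOC(=O)CCC(=O)N1CCN(CCCOc2cc3c(Nc4ccc(F)c(Cl)c4)ncnc3cc2OC)CC1`: 88.6%

These three share one core and differ only in the length of the saturated chain on the ester. In a functional assay on A549 cells (Homo sapiens) for cytotoxicity, read by MTT assay, with a stated time of 24 h, tested at 40 uM (a lower number here means a stronger effect, a higher number a weaker effect of the compound at the concentration tested), the change from compound 1 to compound 2 is methyl in place of hydrogen on a saturated chain carbon, ten or more bonds along the chain from an oxygen next to a carbonyl group, and the step reads a number 6.3 percentage points lower from compound 1 to compound 2 (within the scatter). The difference between compound 1 and compound 3 is propyl in place of hydrogen on a saturated chain carbon, ten or more bonds along the chain from an oxygen next to a carbonyl group, with a step of a number 76.6 percentage points higher from compound 1 to compound 3 (beyond the scatter); from compound 2 to compound 3 the step is a number 82.9 percentage points higher from compound 2 to compound 3 (beyond the scatter). Compound 3 thus shows the weakest effect of the three.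

Compound 4, `CCCCCCCCCCCCCCCOC(=O)CCC(=O)N1CCN(CCCOc2cc3c(Nc4ccc(F)c(Cl)c4)ncnc3cc2OC)CC1`, has not yet been measured. It differs from compound 3 by methyl in place of hydrogen on a saturated chain carbon, ten or more bonds along the chain from an oxygen next to a carbonyl group, the same change as that from compound 1 to compound 2, now made on the core of compound 3. The earlier step, a number 6.3 percentage points lower from compound 1 to compound 2 (within the scatter), stayed within the scatter, and compound 3 already sits near the top of the range, so the expected step is about a number 8.6 percentage points lower from compound 3 to compound 4 (within the scatter). That expectation rests on the small earlier step alone; the large step from compound 2 to compound 3 shows that adding one methyl in place of hydrogen can move the read-out strongly, and the three measured compounds give no firm direction for a further one. Compound 4 is therefore estimated at 80%, with a range from 45% to 100%.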

Compound 4, a percentage reported as activity, at one concentration (the size of the read-out at that concentration, not a potency): 85.5%
Compound 4: middle estimate off by 5.5 percentage points, on the low side, and the stated range covers the measured number.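

In this assay, methyl in place of hydrogen gives a number 3.1 percentage points lower from compound 3 to compound 4 (within the scatter), a small step that agrees with the one seen on the shorter chain: the same change on two cores in this assay, a number 6.3 percentage points lower (within the scatter) from compound 1 to compound 2 and a number 3.1 percentage points lower (within the scatter) from compound 3 to compound 4, 3.2 percentage points apart, within the scatter of two such steps. Propyl in place of hydrogen gives a number 79.8 percentage points higher from compound 2 to compound 4 (beyond the scatter), matching its earlier counterpart, while butyl in place of hydrogen gives a number 73.5 percentage points higher from compound 1 to compound 4 (beyond the scatter): the same change on two cores in this assay, a number 76.6 percentage points higher (beyond the scatter) from compound 1 to compound 3 and a number 79.8 percentage points higher (beyond the scatter) from compound 2 to compound 4, 3.2 percentage points apart, within the scatter of two such steps. Among these four compounds, the methyl and propyl changes therefore each carry over from one core to another with a similar step, but this does not show that they would do so on other cores, and it does not explain the large step seen with ethyl in place of hydrogen, a number 82.9 percentage points higher from compound 2 to compound 3 (beyond the scatter), which has no counterpart here on a second core.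

The compounds shown leave open where between the chains of compound 2 and compound 3 the read-out changes, since no chain of intermediate length appears among them. They also leave open how a longer chain, or a carboxylic acid in place of the ester, would behave in this assay.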